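The source may hold more compounds than are shown below. What is called first, only, known or untested is meant among the compounds shown, and "the series" means these compounds.

Measured compounds:
compound 1 `CC(=O)OC[C@H]1O[C@@H](n2cc(-c3cn(Cc4ccc(C(C)C)cc4)nn3)c(=O)[nH]c2=O)C[C@@H]1OC(C)=O` — 96.5%
compound 2 `CC(=O)OC[C@H]1O[C@@H](n2cc(-c3cc(-c4ccc(C(C)(C)C)cc4)no3)c(=O)[nH]c2=O)C[C@@H]1OC(C)=O` — 53.8%
compound 3 `CC(=O)OC[C@H]1O[C@@H](n2cc(-c3cc(-c4ccccc4)no3)c(=O)[nH]c2=O)C[C@@H]1OC(C)=O` — 92.2%

In a functional assay on HCT-15 cells (Homo sapiens) for cytotoxicity, read by sulforhodamine B assay, tested at 10 uM (on this read-out lower numbers stand for less inhibition and higher numbers for more inhibition at the one concentration tested (going by the name of the read-out)), compound 3 stands second highest of the three numbers. Compound 1 gives 96.5%, which lies within the scatter of compound 3, whereas compound 2 sits well lower. Compound 4 `CCCCc1ccc(-c2cc(-c3cn([C@H]4C[C@H](OC(C)=O)[C@@H](COC(C)=O)O4)c(=O)[nH]c3=O)on2)cc1` differs from compound 3 by butyl in place of hydrogen on an aromatic carbon. Among the measured compounds shown here, one measured step bears on this change: a number 38.4 percentage points higher from compound 2 to compound 3 (beyond the scatter), a large rise when an alkyl group left that same place on the ring. Putting butyl there is expected to run the other way, though butyl is not tert-butyl, so the size is uncertain. The step of a number 27.2 percentage points lower from compound 3 to compound 4 (beyond the scatter) is therefore expected to be downward. Compound 4 is estimated at 65%, within 40% to 92%.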

Compound 4, a percentage reported as inhibition, at one concentration (the size of the read-out at that concentration, not a potency): 71.4%
Compound 4: the middle estimate sits 6.4 percentage points below what was measured; low and high end bracket the measured number.
By their numbers in this assay, from the lowest: compound 2; then compound 4; then compounds 3 and 1 (each within the scatter of the next).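

In this assay the change from phenyl to 4-butylphenyl gives a number 20.8 percentage points lower from compound 3 to compound 4 (beyond the scatter), so the drop seen with tert-butyl at this place is not unique to that branched group. The two alkyl groups still do not read alike, since butyl in place of tert-butyl gives a number 17.6 percentage points higher from compound 2 to compound 4 (beyond the scatter). Nothing measured here gives a reason for either step.

From the compounds shown here alone, how a methyl group or a longer chain such as octyl would read at this place stays open. So does the effect of an amine or a carboxylic acid there.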